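The source may hold more compounds than are shown below. What is called first, only, known or untested is meant among the compounds shown, and "the series" means these compounds.

Values in a functional assay (muscle tissue) with Cavia porcellus as the target; on this read-out lower numbers stand for an effect already at smaller amounts and higher numbers for an effect only at larger amounts of compound:
- compound 1 `COC(=O)C1=C(C)N=C(C)/C(=C(\O)OC)C1c1ccccc1OC`: 57.5 nM
- compound 2 `COC(=O)C1=C(C)N=C(C)/C(=C(\O)OC)C1c1cccc(Cl)c1Cl`: 19.1 nM
- compound 3 `COC(=O)C1=C(C)N=C(C)/C(=C(\O)OC)C1c1ccccc1C`: not yet measured

Within the data shown here, of the two measured compounds, compound 2 has the lower number, 19.1 nM, and its only neighbour is compound 1 at 57.5 nM. Compound 3 shares the core of compound 2 but differs in one place: 2-methylphenyl in place of 2,3-dichlorophenyl on a saturated ring carbon. In words, 2-methylphenyl stands in place of 2,3-dichlorophenyl on a saturated ring carbon, next to the ring atom that bears a methoxycarbonyl group.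

Among the measured compounds shown here, only one measured step bears on this change. It is a 3.0-fold lower number from compound 1 to compound 2 (0.48 log units; beyond the scatter), a modest step at the same ring carbon. The 2-methylphenyl of compound 3 is closer by name to the 2-methoxyphenyl of compound 1 than to the group it replaces, so part of that step is expected to be given back in this assay. A modest move towards a higher number is therefore expected, though a single step is thin support. The expected change is a 2.1-fold higher number from compound 2 to compound 3 (0.32 log units; beyond the scatter). For compound 3 the estimated value is 40 nM, with an expected range from 12 nM to 130 nM.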

Compound 3, half-maximal effective concentration: 6.03 nM
Estimate against measurement, compound 3: 6.6-fold (0.82 log units) above; measured number below the stated range.
By their numbers in this assay, from the lowest: compound 3; then compound 2; then compound 1.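

In this assay, the 2-methylphenyl group gives a 3.2-fold lower number from compound 2 to compound 3 (0.50 log units; beyond the scatter), so the two chlorines of 2,3-dichlorophenyl are not needed for a low number at this saturated ring carbon, and compound 3 now has the lowest number of the three. The exchange of methyl for methoxy on an aromatic carbon gives a 9.5-fold lower number from compound 1 to compound 3 (0.98 log units; beyond the scatter), which shows that this single change on the phenyl ring moves the number further than either of the other two steps at this position, and that the closeness of two group names says little about how close their numbers will be. The data offer no measurement that explains this order.

It remains open whether a phenyl ring carrying a single chlorine, an ethyl or an amine would keep a number as low as that of compound 3, so the three aryl groups shown do not establish a trend. Going by these compounds, it is also open how this ranking would hold if the methoxycarbonyl group of the shared core gave way to a longer ester chain or a carboxylic acid.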